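Cyano for Methoxy Across Two Related Cores

The source may report more compounds than this note shows. Statements on the series, on what has been measured and on what is new or still open speak of the compounds shown alone.

Compound 1 `COc1ccc(CN2c3ccccc3C(=O)N(Cc3ccccc3)S2(=O)=O)cc1` carries a methoxy group on a benzyl arm attached to its core. In a functional assay on MRC5 cells (Homo sapiens) (a lower number here means that less compound is tolerated, a higher number that more compound is tolerated), compound 1 gives 61000 nM. Compound 3 `N#Cc1ccc(CN2c3ccccc3C(=O)N(Cc3ccccc3)S2(=O)=O)cc1` differs from it by a single change, (cyano in place of methoxy on an aromatic carbon), and in this assay compound 3 gives 62000 nM. The step of a 1.0-fold higher number from compound 1 to compound 3 (0.01 log units; within the scatter) lies within the scatter of the assay.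

Compound 2 `COc1ccc(CN2c3ccccc3C(OCc3ccccc3)=NS2(=O)=O)cc1` has the same atoms as compound 1, joined differently; the difference between the two cores is not broken down here. In this assay, among the compounds with values here, compound 2 gives 61000 nM, level with compound 1 at the digits recorded, and the two stand together as the lowest of the three numbers measured so far, with compound 3 within the scatter of both.

Compound 4 `N#Cc1ccc(CN2c3ccccc3C(OCc3ccccc3)=NS2(=O)=O)cc1` has not yet been measured in this assay. It is related to compound 2 by cyano in place of methoxy on an aromatic carbon, the same change that links compound 1 to compound 3, made at a place described in the same words. Because the earlier step of a 1.0-fold higher number from compound 1 to compound 3 (0.01 log units; within the scatter) stayed within the scatter, the step of no change at the digits printed from compound 2 to compound 4 (within the scatter) is expected to be of similar size. On that basis compound 4 is estimated at 61000 nM in this assay, with the likely range running from 35000 nM to 105000 nM; the actual measurement will tell whether the change behaves the same way on the core of compound 2.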

Compound 4, half-maximal cytotoxic concentration: 62000 nM
For compound 4 the middle estimate is 1.0-fold (0.01 log units) below the measured one, within the range that was stated.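

In this assay, putting cyano in place of methoxy on the core of compound 2 gives a step that stays within the scatter (a 1.0-fold higher number from compound 2 to compound 4 (0.01 log units; within the scatter)). Set beside the same change on the core of compound 1, the two steps show no difference, so in this small set the change carries from one core to the other without any visible departure: the same change on two cores in this assay, a 1.0-fold higher number (0.01 log units; within the scatter) from compound 1 to compound 3 and a 1.0-fold higher number (0.01 log units; within the scatter) from compound 2 to compound 4, 1.0-fold (0.00 log units) apart, within the scatter of two such steps. Within the data shown here, this agreement is, however, one between two steps that are both within the scatter, so it shows only that the change leaves the number unmoved on both cores in this assay; it does not show that a change with a step beyond the scatter would carry over in the same way, and it says nothing about any other measurement.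

The compounds shown leave open whether a different group in the same place, such as an amine or a carboxylic acid in place of the cyano of compound 4, would behave alike on the two cores. They also leave open what a longer chain in place of the benzyl group on the other side of each core would do to the number in this assay.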